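From 4-methoxybenzyl to 2,4-difluorobenzyl on the amide

A few compounds are considered here, and "the series" means these few. Any claim that something is new, unique, unknown or untested is made for them only; others in the source may bear on it.

In a functional assay (QGY7701 cells, Homo sapiens) for inhibition, read by MTT assay, with a stated time of 48 h (a lower number here means a stronger inhibitor, a higher number a weaker inhibitor), compound 3 `COc1ccc(CNC(=O)/C=C/c2coc3cc(OC)ccc3c2=O)cc1` gives 15700 nM as its reading, and compound 2 `COc1ccc2c(=O)c(/C=C/C(=O)NCc3cccc(F)c3)coc2c1` gives 28600 nM as its reading. These two readings lie within the scatter of each other, so compound 3 cannot be separated from compound 2. Compound 1 `COc1ccc2c(=O)c(/C=C/C(=O)Nc3cc(C)ccc3C)coc2c1` gives > 100000 nM as its entry, which is a limit and not a number. Leaving compound 1 for a benzyl group on the amide-type nitrogen gave both an at least 3.4-fold lower number from compound 1 to compound 2 (0.54 log units; beyond the scatter) and an at least 6.3-fold lower number from compound 1 to compound 3 (0.80 log units; beyond the scatter) on the two routes.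

Compound 4 `COc1ccc2c(=O)c(/C=C/C(=O)NCc3ccc(F)cc3F)coc2c1` also carries a benzyl group there: 2,4-difluorophenyl in place of 4-methoxyphenyl on a saturated chain carbon bound to an amide-type nitrogen with 2,4-difluorophenyl in place of 4-methoxyphenyl on a saturated chain carbon bound to an amide-type nitrogen. Within the data shown here, the one measured exchange between such benzyl groups gave a 1.8-fold lower number from compound 2 to compound 3 (0.26 log units; within the scatter) and stayed within the scatter, so no step beyond the scatter is expected in this assay here. The estimated step is a 1.4-fold higher number from compound 3 to compound 4 (0.15 log units; within the scatter) and remains an expectation. Compound 4 is expected at 22000 nM as its estimate, with a likely range of 9000 nM to 55000 nM around it.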

Compound 4, half-maximal inhibitory concentration: > 100000 nM
Compound 4: no number, only a limit (the forecaster's own chance of this, stated with the estimate: 10%); at least 4.5-fold (0.65 log units) between middle value and limit.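

In this assay, exchanges among benzyl groups on the amide-type nitrogen are not always silent: 2,4-difluorophenyl in place of 4-methoxyphenyl gave an at least 6.3-fold higher number from compound 3 to compound 4 (0.80 log units; beyond the scatter), and in place of 3-fluorophenyl it gave an at least 3.4-fold higher number from compound 2 to compound 4 (0.54 log units; beyond the scatter). A benzyl group at this place therefore does not by itself secure a measurable reading: compound 2 and compound 3 fit that link, but compound 4 goes against it. Compound 1 and compound 4 each stand at a limit and not a number, so the step between them cannot be read: the limit of > 100000 nM in this assay, at which 2 of the 4 values shown sit.

The compounds shown leave open which of the two fluorines in compound 4 goes with the loss of a measurable reading, a question that 2-fluorobenzyl and 4-fluorobenzyl would separate. They also leave open how an unsubstituted benzyl or a longer chain such as 2-phenylethyl would read on this nitrogen.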